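Methyl added to the 4-chlorophenyl amide of compound 2

A few compounds are considered here, and "the series" means these few. Any claim that something is new, unique, unknown or untested is made for them only; others in the source may bear on it.

The series shares one core, seen in compound 1 `O=C(Nc1ccc(Cl)c(-c2nnc3c(Cl)cccn23)c1)c1ccccn1`, with the amide aryl group varied. In a functional assay on HeLa cells (Homo sapiens) for antiproliferative activity, read by MTT assay, with a stated time of 72 h (on this read-out lower numbers stand for stronger inhibition and higher numbers for weaker inhibition), compound 1 gives 75500 nM and compound 3 `O=C(Nc1ccc(Cl)c(-c2nnc3c(Cl)cccn23)c1)c1ccc(C(F)(F)F)cc1F` gives 61900 nM. For compound 2 `O=C(Nc1ccc(Cl)c(-c2nnc3c(Cl)cccn23)c1)c1ccc(Cl)cc1` this assay returns only a limit, > 100000 nM, so compound 2 stands at the weak end of the numbers shown, without a number of its own. Among the compounds with values here, the one measured step, an at least 1.3-fold higher number from compound 1 to compound 2 (0.12 log units; that floor lies within the scatter), is read against that limit (the limit of > 100000 nM in this assay, at which 1 of the 3 values shown sits).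

Compound 4 `Cc1cc(Cl)ccc1C(=O)Nc1ccc(Cl)c(-c2nnc3c(Cl)cccn23)c1` differs from compound 2 by methyl in place of hydrogen on an aromatic carbon. Within the data shown here, no measured step of this kind exists among the three compounds; the only step bearing on compound 2 is itself bounded by the limit. All three measured values sit within a narrow band at the weak end, so the expected step of a number no higher from compound 2 to compound 4 (the limit leaves the size open) is none beyond the scatter, with a fair chance that compound 4 again returns only a limit. The estimate for compound 4 in this assay is 100000 nM, within 45000 nM to 250000 nM.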

Compound 4, half-maximal inhibitory concentration: > 100000 nM
Compound 4: no number, only a limit; the forecaster's own chance of this, stated with the estimate: 55%; the middle value sits exactly at the limit.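

In this assay compound 4 gives > 100000 nM as a limit and not as a number. The change from pyridin-2-yl to 4-chloro-2-methylphenyl reads as an at least 1.3-fold higher number from compound 1 to compound 4 (0.12 log units; that floor lies within the scatter) and shows no separation beyond the scatter. The step for methyl on this aromatic carbon, ortho to a large group, cannot be read, so the new result adds only a second amide at the same limit: the limit of > 100000 nM in this assay, at which 2 of the 4 values shown sit.

Going by these compounds, whether methyl here changes the antiproliferative number in either direction remains open, as both compounds of the pair lack a number of their own. Also open, on these data alone, is whether an amine or a carboxylic acid on this carbon, with the chloro group kept, would give a measurable value in this assay rather than a limit.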